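Pyridyl variants on the shared core: toward compound 4

The source may report more compounds than this note shows. Statements on the series, on what has been measured and on what is new or still open speak of the compounds shown alone.

compound 1 `Cc1cccc(-c2noc(C(C)NC(=O)c3cc(C4CC4)nn3C)n2)c1`: 1880 nM
compound 2 `Cc1cccc(-c2nc(C(C)NC(=O)c3cc(C(F)(F)F)nn3C)no2)c1`: 977 nM
compound 3 `Cc1ccnc(-c2noc([C@H](C)NC(=O)c3cc(C(F)(F)F)nn3C)n2)c1`: 4470 nM

In an assay on T-REx-293 cells for inhibition of potassium channel subfamily T member 1 (Homo sapiens), read by patch clamp (on this read-out lower numbers stand for stronger inhibition and higher numbers for weaker inhibition), compound 3 stands at the highest of the three numbers. Compound 1 sits at a lower number, and compound 2 at a lower number still; both gaps to compound 3 are beyond the usual scatter. Compound 4 `COCc1cc(-c2noc([C@H](C)NC(=O)c3cc(C(F)(F)F)nn3C)n2)ccn1` has not yet been measured in this assay. It differs from compound 3 by 2-(methoxymethyl)pyridin-4-yl in place of 4-methylpyridin-2-yl on an aromatic carbon. Among the compounds with values here, no measured pair carries this change, so no direction can be read from the data. The estimate for compound 4 is 3500 nM, with a range from 1000 nM to 12000 nM. The implied step a 1.3-fold lower number from compound 3 to compound 4 (0.11 log units; within the scatter) is expected to stay within the scatter, with wide uncertainty either way.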

Compound 4, half-maximal inhibitory concentration: 322 nM
Compound 4: middle estimate off by 11-fold (1.04 log units), on the high side, outside the stated range (below it).
By their numbers in this assay, from the lowest: compound 4; then compounds 2 and 1 (each within the scatter of the next); then compound 3.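

Within the data shown here, on an aromatic carbon between two ring nitrogen atoms, 2-(methoxymethyl)pyridin-4-yl in place of 4-methylpyridin-2-yl gives a 14-fold lower number from compound 3 to compound 4 (1.14 log units; beyond the scatter) in this assay and so shows that this position is sensitive to the group it carries, which no earlier pair could show. Nothing measured here accounts for the step.

The change alters the pyridine attachment and the side chain together, so the share of each remains unresolved. Also open, as far as these compounds go, is how a hydroxymethyl or aminomethyl group on the pyridin-4-yl ring would compare with methoxymethyl.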